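The source may report more compounds than this note shows. Statements on the series, on what has been measured and on what is new or still open speak of the compounds shown alone.

Three compounds have been measured in a functional assay on SEM cells (Homo sapiens) for cytotoxicity, with a stated time of 72 h; a lower number here means that less compound is needed, a higher number that more compound is needed for the effect:

Compound 1, `C=C[C@@](C)(/C=C/c1ccc(OS(=O)(=O)C(F)(F)F)cc1)CCC=C(C)C`, gives > 36600 nM, which is a limit of the assay rather than a number.
Compound 2, `C=C[C@@](C)(/C=C/c1ccc(OS(=O)(=O)c2ccc(C)cc2)cc1)CCC=C(C)C`, gives > 43400 nM, also a limit.
Compound 3, `CCOC(=O)/C(C)=C/c1cc(/C=C/[C@](C)(/C=C/c2ccc(OC)cc2)CCC=C(C)C)ccc1O`, gives > 36600 nM, again a limit.

Compound 1 therefore stands at the edge of what this assay can report, and since every other value shown is a limit as well, it cannot be placed above or below compound 2 or compound 3. For the measured compounds named here, the one change between measured compounds that touches compound 1, a step that the two limits leave unreadable from compound 1 to compound 2, is left unreadable by the two limits, as the limit of > 36600 nM in this assay, at which 2 of the 3 values shown sit, and the limit of > 43400 nM in this assay, at which 1 of the 3 values shown sits, together record. The compound under consideration, compound 4, `C=C[C@@](C)(/C=C/c1ccc(-c2cccc(Br)c2)cc1)CCC=C(C)C`, differs from compound 1 by 3-bromophenyl in place of ((trifluoromethyl)sulfonyl)oxy on an aromatic carbon. Going by the values given here, no measured step bears readably on this change, so no direction can be drawn from the data in this assay. The account therefore expects compound 4 to sit near the same limit, and the step that the limit leaves unreadable from compound 1 to compound 4 is expected to be no more than the scatter allows. For compound 4 the estimate in this assay is 40000 nM, with a range from 10000 nM to 150000 nM.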

Compound 4, half-maximal effective concentration: > 36600 nM
Compound 4: a limit, no number; the forecaster's own chance of this, stated with the estimate: 70%; the middle value lies beyond the limit too.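

In this assay compound 4 gives > 36600 nM, a limit of the assay and not a number. Its step from compound 1 therefore cannot be read, so compound 1 and compound 4 cannot be placed relative to each other. The compounds shown leave open whether any change to the shared core would give a readable value in this assay.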